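The compounds below may be only part of what the source reports. "The series", "measured", "known", "first", "only" and "open" are said of these compounds alone.

In an assay on isolated protein for inhibition of Amine oxidase [flavin-containing] A (Homo sapiens), read by fluorescence (a higher number here means a weaker inhibitor, a lower number a stronger inhibitor), the three measured compounds all give large numbers. Compound 1 `O=C(/C=C/c1ccoc1)c1cc(O)c(O)c([N+](=O)[O-])c1` gives 52900 nM, compound 2 `N#Cc1ccc(/C=C/C(=O)c2cc(O)c(O)c([N+](=O)[O-])c2)cc1` gives 45300 nM and compound 3 `CC(=O)N1N=C(c2cc(O)c(O)c([N+](=O)[O-])c2)CC1c1nccs1` gives 84600 nM. Compound 3 carries the highest of the three numbers, yet its gaps to compound 1 and to compound 2 both lie within the scatter, so no order among them can be read. Compound 4 `CC(=O)N1N=C(c2cc(O)c(O)c([N+](=O)[O-])c2)CC1c1cccc(O)c1` differs from compound 3 in one place: 3-hydroxyphenyl in place of 1,3-thiazol-2-yl on a saturated ring carbon. Going by the values given here, no pair of measured compounds shows this change, so nothing is known about what it does here. With all three numbers so close, compound 4 is expected to stay in the same region, with the step of a 1.2-fold lower number from compound 3 to compound 4 (0.08 log units; within the scatter) not beyond the scatter. Compound 4 is therefore estimated at 70000 nM in this assay, between 30000 nM and 160000 nM.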

Compound 4, half-maximal inhibitory concentration: 87000 nM
Compound 4: the middle estimate sits 1.2-fold (0.09 log units) below what was measured; measured number inside the range.
By their numbers in this assay, from the lowest: compounds 2, 1, 3 and 4 (each within the scatter of the next).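

In this assay the step of a 1.0-fold higher number from compound 3 to compound 4 (0.01 log units; within the scatter) lies within the scatter, so at this saturated ring carbon 3-hydroxyphenyl and 1,3-thiazol-2-yl cannot be told apart. Going by these compounds alone, this is the first reading at this position, and it shows that a six-membered aromatic ring of carbon only, bearing a hydrogen-bond donor, gives a number indistinguishable from that of the five-membered ring with two hetero atoms. No supporting measurement bears on this result. Still open, as far as these compounds go, is whether an amine or a carboxylic acid at this carbon would give a number beyond the scatter.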